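The source may hold more compounds than are shown below. What is called first, only, known or untested is meant among the compounds shown, and "the series" means these compounds.

Measured in a functional assay on NCI-H1581 cells (Homo sapiens) for inhibition, read by MTT assay, with a stated time of 48 h, tested at 10 uM; on this read-out higher numbers stand for more inhibition at the one concentration tested (going by the name of the read-out) and lower numbers for less inhibition:
compound 1 `COc1cc(NC(=O)Nc2cc(Nc3ccc(C(C)(C)C)cc3)ncn2)cc(OC)c1`: 38.7%
compound 2 `COc1cc(NC(=O)Nc2cc(Nc3cccc(C(C)(C)C)c3)ncn2)cc(OC)c1`: 35.1%

Going by the values given here, compound 2 and compound 1 lie within the scatter of each other; the single measured step, a number 3.6 percentage points lower from compound 1 to compound 2 (within the scatter), carries no signal. Compound 3 `COc1cc(NC(=O)Nc2cc(Nc3ccc(F)c(Cl)c3)ncn2)cc(OC)c1` is not yet measured. Change: 3-chloro-4-fluorophenyl in place of 3-(tert-butyl)phenyl on a nitrogen on an aromatic ring. Among the compounds with values here, no measured step places a 3-chloro-4-fluorophenyl group on a nitrogen on an aromatic ring, so the swap of one aryl group for another at that nitrogen is the only point of comparison, and it showed no change beyond the scatter. The expected step is a number 0.1 percentage points lower from compound 2 to compound 3 (within the scatter), none beyond the scatter, on thin grounds. For compound 3 the estimate is 35%, range 15% to 60%.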

Compound 3, a percentage reported as inhibition, at one concentration (the size of the read-out at that concentration, not a potency): 53%
For compound 3 the middle estimate is 18 percentage points below the measured one, and the stated range covers the measured number.
By their numbers in this assay, from the lowest: compounds 2 and 1 (each within the scatter of the next); then compound 3.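

In this assay, 3-chloro-4-fluorophenyl in place of 3-(tert-butyl)phenyl gives a number 17.9 percentage points higher from compound 2 to compound 3 (beyond the scatter), and in place of 4-(tert-butyl)phenyl it gives a number 14.3 percentage points higher from compound 1 to compound 3 (beyond the scatter). The aryl group on the nitrogen therefore does affect this read-out, which the move of the tert-butyl group alone did not show. No evidence here explains the step.

Open, as far as these compounds go, is whether chlorine alone or fluorine alone would carry the step. Also open, from the compounds shown here alone, is how an aryl group bearing a morpholine or a carboxylic acid would read at that nitrogen.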